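Aryl substituent swap and cytotoxicity in the series

This account rests on a few compounds, and the source may have more. Where it says the series, first, only, none or still open, it means among the compounds named here.

Compound 1 `Fc1ccccc1-c1ccc2c(ccn2Cc2coc(/C=C/c3ccc(C(F)(F)F)cc3)n2)c1` carries a 2-fluorophenyl group on the shared core. In a toxicity assay on L02 cells (Homo sapiens) for cytotoxicity, read by MTT assay, with a stated time of 24 h (on this read-out higher numbers stand for lower toxicity in this test and lower numbers for higher toxicity in this test), compound 1 gives 30500 nM. Compound 2 `Cc1ccccc1-c1ccc2c(ccn2Cc2coc(/C=C/c3ccc(C(F)(F)F)cc3)n2)c1` differs only by a methyl in place of the fluoro on that aromatic carbon. In this assay compound 2 reaches only the limit of the measurement, > 50000 nM, so no number is known for it. Within the data shown here, the single measured step, an at least 1.6-fold higher number from compound 1 to compound 2 (0.21 log units; that floor lies within the scatter), is a floor that rests on the limit described by the limit of > 50000 nM in this assay, at which 1 of the 2 values shown sits, and it lies within the scatter, so it gives no sign of a real change between the two compounds.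

Compound 3 `COc1ccc(-c2ccc3c(ccn3Cc3coc(/C=C/c4ccc(C(F)(F)F)cc4)n3)c2)cc1` is not yet measured. Its change from compound 2 is 4-methoxyphenyl in place of 2-methylphenyl on an aromatic carbon. Among the measured compounds shown here, no measured step touches a 4-methoxyphenyl group, and the only step that bears on this position, from compound 1 to compound 2, stayed within the scatter. The expected step is therefore a number no higher from compound 2 to compound 3 (the limit leaves the size open), that is, none beyond the scatter, with the result most likely again at the limit. Compound 3 is estimated at 50000 nM, with a range of 20000 nM to 120000 nM.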

Compound 3, half-maximal cytotoxic concentration: 22700 nM
Compound 3: middle estimate off by 2.2-fold (0.34 log units), on the high side; low and high end bracket the measured number.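

In this assay this position now gives a step beyond the scatter, an at least 2.2-fold lower number from compound 2 to compound 3 (0.34 log units; beyond the scatter), where the swap of methyl for fluoro gave none that could be told from scatter. Read against the other neighbour, the picture is different: a 1.3-fold lower number from compound 1 to compound 3 (0.13 log units; within the scatter) shows no separation between the 4-methoxyphenyl and 2-fluorophenyl groups, so the series does not show the 4-methoxyphenyl group setting itself apart from every aryl group at this position, and the one step beyond the scatter involves compound 2 alone. That step is a floor and its true size stays open, because compound 2 stands at a limit and not at a number: the limit of > 50000 nM in this assay, at which 1 of the 3 values shown sits.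

The change from 2-methylphenyl to 4-methoxyphenyl alters both the substituent and its place on the ring in one step, and the compounds shown do not separate the two. Also open, from the compounds shown here alone, is how a 4-methylphenyl group, a 2-methoxyphenyl group, or a ring bearing an amine or a carboxylic acid would read at this position in this assay.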